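Chloro for hydroxy on the cinnamamide aryl ring

The source may hold more compounds than are shown below. What is called first, only, known or untested is meant among the compounds shown, and "the series" means these compounds.

Compound 2 `CCCc1cc(N)c2cc(NC(=O)/C=C/c3ccc(O)cc3)ccc2n1` sits at the weak end of the three numbers in hand: in an assay on isolated protein for displacement of a labelled ligand from melanin-concentrating hormone receptor 1 (Homo sapiens) (on this read-out lower numbers stand for stronger inhibition and higher numbers for weaker inhibition), compound 2 gives 1100 nM, while compound 1 `CCCc1cc(N)c2cc(NC(=O)/C=C/c3ccc(N)cc3)ccc2n1` gives 190 nM and compound 3 `CCCc1cc(N(C)C)c2cc(NC(=O)/C=C/c3ccc(C(F)(F)F)cc3)ccc2n1` gives 43 nM. For the measured compounds named here, the one measured single-point step, a 5.8-fold higher number from compound 1 to compound 2 (0.76 log units; beyond the scatter), shows the hydroxy analogue trailing its amino counterpart by a margin beyond the scatter. Compound 4 `CCCc1cc(N)c2cc(NC(=O)/C=C/c3ccc(Cl)cc3)ccc2n1` has not yet been measured; it differs from compound 2 by chloro in place of hydroxy on an aromatic carbon. Going by the values given here, no measured step swaps the hydroxy for a halogen, so the expectation rests on compound 1 and compound 3. Because compound 1 reaches 190 nM without the hydroxy, and because compound 3 reaches 43 nM with a trifluoromethyl group in that place alongside a dimethylamino on the core, the chloro analogue is expected to improve on compound 2 by a step of a 5.5-fold lower number from compound 2 to compound 4 (0.74 log units; beyond the scatter). Compound 4 is therefore estimated at 200 nM in this assay, within a range from 60 nM to 700 nM.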

Compound 4, half-maximal inhibitory concentration: 6 nM
Compound 4: the middle estimate sits 33-fold (1.52 log units) above what was measured; the whole stated range lies above it.
By their numbers in this assay, from the lowest: compound 4; then compound 3; then compound 1; then compound 2.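

In this assay the change from 4-hydroxyphenyl to 4-chlorophenyl, on an aromatic carbon para to a large group, gives a 180-fold lower number from compound 2 to compound 4 (2.26 log units; beyond the scatter) and is a large step. Chloro also outruns amino at the same place, with a 32-fold lower number from compound 1 to compound 4 (1.50 log units; beyond the scatter), so the gap between amino and hydroxy seen earlier covered only a small part of what this position can span. Nothing measured here accounts for the size of these steps.

The compounds shown leave open whether fluoro, bromo, methyl or methoxy at this place would match chloro. They also leave open whether the gain from chloro would persist with a dimethylamino group in place of the amino group on the shared core.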